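Cyclohexylmethyl replacing benzyl on the sulfonamide nitrogen

The compounds below may be only part of what the source reports. "The series", "measured", "known", "first", "only" and "open" are said of these compounds alone.

Among the measured compounds shown here, compound 3 `O=C1c2ccccc2N(Cc2ccccc2)S(=O)(=O)N1Cc1ccccc1` is the one member of the series with a number in a functional assay on MRC5 cells (Homo sapiens); on this read-out lower numbers stand for higher toxicity in this test and higher numbers for lower toxicity in this test: compound 3 gives 66000 nM. Compound 1 `O=C1c2ccccc2N(Cc2ccc([N+](=O)[O-])cc2)S(=O)(=O)N1Cc1ccccc1` reaches only a limit, > 59000 nM. Compound 2 `O=C1c2ccccc2N(Cc2ccccc2-c2ccccc2)S(=O)(=O)N1Cc1ccccc1` likewise reaches only a limit, > 55000 nM. The steps a step that the limit leaves unreadable from compound 1 to compound 3 and a step that the limit leaves unreadable from compound 2 to compound 3 therefore carry no readable size, as the limit of > 59000 nM in this assay, at which 1 of the 3 values shown sits, and the limit of > 55000 nM in this assay, at which 1 of the 3 values shown sits, show. Compound 4 `O=C1c2ccccc2N(CC2CCCCC2)S(=O)(=O)N1Cc1ccccc1` differs from compound 3 by cyclohexyl in place of phenyl on a saturated chain carbon bound to a sulfonamide nitrogen in a ring; cut one bond further out, the change reads benzyl to cyclohexylmethyl. For the measured compounds named here, no measured step bears on this change, so the expectation rests on compound 3 alone, with no step beyond the scatter expected in this assay. Compound 4 is therefore estimated at 60000 nM, between 25000 nM and 150000 nM. The expected step of a 1.1-fold lower number from compound 3 to compound 4 (0.04 log units; within the scatter) is essentially flat.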

Compound 4, half-maximal cytotoxic concentration: > 65000 nM
Compound 4: a limit, no number; the forecaster's own chance of this, stated with the estimate: 50%; middle value at least 1.0-fold (0.03 log units) away from the limit.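

In this assay compound 4 reaches only a limit, > 65000 nM, so its steps from compound 3 and compound 1 cannot be read. From the compounds shown here alone, whether benzyl to cyclohexylmethyl shifts this read-out at all remains open.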